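This account rests on a few compounds, and the source may have more. Where it says the series, first, only, none or still open, it means among the compounds named here.

Compound 1 `CN(C)[C@H]1CCN(c2cccc3c2C[C@H](CN(C)[C@H]2CCCc4cccnc42)NC3)C1` is the least stable of the three measured compounds in an ADME assay on microsomes from liver (Homo sapiens) for metabolic stability, using NADPH, with a stated time of 10 min (a lower number here means that less of the compound is left, a higher number that more of the compound is left), giving 67.5%. Compound 2 `CN1CCN(Nc2cccc3c2C[C@@H](CN(C)[C@H]2CCCc4cccnc42)NC3)CC1` gives 73.6% in this assay, which lies within the scatter of compound 1. Compound 3 `CN(C)C1CCN(c2cccc3c2C[C@H](CN(C)[C@H]2CCCc4cccnc42)NC3)CC1` gives 78.4%, and the step of a number 10.9 percentage points higher from compound 1 to compound 3 (beyond the scatter) is modest. Compound 4 `CN1CC[C@H]2CN(c3cccc4c3C[C@H](CN(C)[C@H]3CCCc5cccnc53)NC4)C[C@H]21` differs from compound 1 by a change (a group of 9 heavy atoms (7 carbon, 2 nitrogen; 2 five-membered non-aromatic rings with 1 hetero atom each) in place of a group of 8 heavy atoms (6 carbon, 2 nitrogen; one five-membered non-aromatic ring with 1 hetero atom), on an aromatic carbon). Among the compounds with values here, the only measured step that touches the same position is a number 10.9 percentage points higher from compound 1 to compound 3 (beyond the scatter), where exchanging the group on that aromatic carbon moved the number by a modest amount. A similar, small rise is therefore expected for compound 4, possibly within the scatter, as a number 6.5 percentage points higher from compound 1 to compound 4 (within the scatter). Compound 4 is thus estimated at 74% in this assay, between 62% and 86%.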

Compound 4, percent of the compound remaining: 87.3%
Compound 4: the middle estimate sits 13.3 percentage points below what was measured, and the stated range ends below it.
By their numbers in this assay, from the lowest: compounds 1, 2, 3 and 4 (each within the scatter of the next, the first and the last beyond it).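

Exchanging 3-(dimethylamino)pyrrolidin-1-yl for the group with 2 five-membered non-aromatic rings gives a number 19.8 percentage points higher from compound 1 to compound 4 (beyond the scatter) in this assay so a second, different group on this aromatic carbon also clears the scatter. The step of a number 8.9 percentage points higher from compound 3 to compound 4 (within the scatter) leaves compound 4 and the 4-(dimethylamino)piperidin-1-yl group of compound 3 indistinguishable here. Nothing available explains these differences. From the compounds shown here alone, it remains open whether a morpholin-4-yl or a plain dimethylamino group on this carbon would match them, and whether the two stereocentres of the entering group matter.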